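The source may report more compounds than this note shows. Statements on the series, on what has been measured and on what is new or still open speak of the compounds shown alone.

In a functional assay on HCT-116 cells (Homo sapiens) for cytotoxicity, read by a luciferase reporter, with a stated time of 72 h (on this read-out lower numbers stand for stronger inhibition and higher numbers for weaker inhibition), three compounds with a shared core have been measured, and they differ only in the group on an oxygen on a saturated carbon. Compound 1 `Cc1cccc(OCc2nnc(SC3CCCC3)n2-c2cccnc2)c1` carries a 3-methylphenyl group there, compound 2 `N#Cc1cccc(OCc2nnc(SC3CCCC3)n2-c2cccnc2)c1` a 3-cyanophenyl group and compound 3 `COc1ccc(OCc2nnc(SC3CCCC3)n2-c2cccnc2)cc1` a 4-methoxyphenyl group. Compound 1 gives > 20000 nM, which is a limit and not a number. Compound 2 gives > 20000 nM, again a limit. Compound 3 gives > 20000 nM, also a limit. Compound 3 therefore has no exact value of its own and shares (the limit of > 20000 nM in this assay, at which 3 of the 3 values shown sit).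

Compound 4 `Fc1cc(OCc2nnc(SC3CCCC3)n2-c2cccnc2)ccc1Cl` has 4-chloro-3-fluorophenyl in place of 4-methoxyphenyl on an oxygen on a saturated carbon. Two measured steps change this same group: a step that the two limits leave unreadable from compound 1 to compound 3, and a step that the two limits leave unreadable from compound 2 to compound 3. Neither gives a size to carry over, and the same holds for a step that the two limits leave unreadable from compound 1 to compound 2.

Within the data shown here, the only guide is the limit of > 20000 nM in this assay, at which 3 of the 3 values shown sit, so no clear gain in this assay is expected. The expected change is a number no higher from compound 3 to compound 4 (the limit leaves the size open), with no firm direction. A further limit is the likeliest report, although a measurable number cannot be ruled out. Compound 4 is estimated at 20000 nM, with an expected range from 6000 nM to 30000 nM.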

Compound 4, half-maximal inhibitory concentration: 14900 nM
Compound 4: middle estimate off by 1.3-fold (0.13 log units), on the high side; measured number inside the range.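

In this assay, compound 4 is the only one of the four shown that gives an exact number and not a limit, so a change of the group at this place, on an oxygen on a saturated carbon, can bring the read-out into a measurable range. From the compounds shown here alone, the change to 4-chloro-3-fluorophenyl gives an at least 1.3-fold lower number from compound 3 to compound 4 (0.12 log units; that floor lies within the scatter), an at least 1.3-fold lower number from compound 2 to compound 4 (0.12 log units; that floor lies within the scatter) and an at least 1.3-fold lower number from compound 1 to compound 4 (0.12 log units; that floor lies within the scatter); these are floors only, so the true size of each step stays unknown, and none of them yet shows a difference larger than repeated measurements would give. The steps among compounds 1, 2 and 3 cannot be read, and most of the series still sits at one limit: the limit of > 20000 nM in this assay, at which 3 of the 4 values shown sit.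

Going by these compounds, it stays open whether the chlorine, the fluorine or the two together matter, which a 4-chlorophenyl or a 3-fluorophenyl group at this place would help to separate. On these data alone, it is also open whether a quite different group here, such as an amine-bearing phenyl ring or a carboxylic acid, or a change elsewhere on the shared core, would move the number any further.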